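Carbamoyl for cyano on the thiazole of compound 2

A few compounds are considered here, and "the series" means these few. Any claim that something is new, unique, unknown or untested is made for them only; others in the source may bear on it.

Going by the values given here, compound 2 `CC(C)[C@H](C(=O)Nc1ncc(C#N)s1)c1ccc(Cl)cc1` gives 2000 nM in a functional assay on CHO cells for agonist activity at Free fatty acid receptor 2 (Homo sapiens), read by cAMP accumulation (on this read-out lower numbers stand for stronger inhibition and higher numbers for weaker inhibition), the lowest of the two numbers so far. Compound 1 `CC(C)[C@H](C(=O)Nc1nncs1)c1ccc(Cl)cc1` gives 12000 nM in this assay; the step of a 6.0-fold lower number from compound 1 to compound 2 (0.78 log units; beyond the scatter) is the only one measured. Compound 3 `CC(C)[C@H](C(=O)Nc1ncc(C(N)=O)s1)c1ccc(Cl)cc1` differs from compound 2 by carbamoyl in place of cyano on an aromatic carbon. Among the compounds with values here, no measured step exchanges this group, so the step from compound 1 to compound 2 bears only indirectly, showing that the ring on the amide nitrogen moves the number. The step of a 2.0-fold higher number from compound 2 to compound 3 (0.30 log units; within the scatter) is expected to be small. Compound 3 is estimated at 4000 nM, with a range from 1000 nM to 16000 nM.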

Compound 3, half-maximal inhibitory concentration: 71000 nM
Compound 3: middle estimate off by 18-fold (1.25 log units), on the low side, outside the stated range (above it).
By their numbers in this assay, from the lowest: compound 2; then compound 1; then compound 3.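

In this assay, the aromatic carbon next to the ring sulfur does not tolerate this exchange silently: carbamoyl in place of cyano gives a 36-fold higher number from compound 2 to compound 3 (1.55 log units; beyond the scatter), beyond the scatter and larger than a 6.0-fold lower number from compound 1 to compound 2 (0.78 log units; beyond the scatter). The exchange brings 1 hydrogen-bond donor where cyano has 0, and 3 heavy atoms where cyano has 2. No measurement at hand accounts for the size of this step. Which of these differences tracks the higher number remains open. An acetyl group or a methyl ester on this carbon would keep the carbonyl without the amide hydrogens.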